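From Benzyl Ether to Aryl Carbamate: What to Expect

The source may report more compounds than this note shows. Statements on the series, on what has been measured and on what is new or still open speak of the compounds shown alone.

Three compounds on one shared core have been run in a functional assay on PANC-1 cells (Homo sapiens) for inhibition, read by MTT assay, with a stated time of 24 h, tested at 10 uM; on this read-out lower numbers stand for less inhibition and higher numbers for more inhibition at the one concentration tested (going by the name of the read-out). Compound 1 `CC(C)=CCC1Cc2c(OCc3ccccc3)cc(=O)n(CCCO)c2CC1(C)C` gives -0.3%. Compound 2 `CC(C)=CCC1Cc2c(OCCCNS(=O)(=O)c3ccc([N+](=O)[O-])cc3)cc(=O)n(CCCO)c2CC1(C)C`, which bears a different group on the aromatic oxygen, gives 47.7%. Compound 3 `CC(C)=CCC/C(C)=C/CC1Cc2c(OCc3ccccc3)cc(=O)n(CCCO)c2CC1(C)C` gives 46.5%, the second highest of the three numbers: it sits within the scatter of compound 2 and far beyond compound 1, the latter gap being the step of a number 46.8 percentage points higher from compound 1 to compound 3 (beyond the scatter), which lengthens the chain on the ring.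

Compound 4 `CC(C)=CCC/C(C)=C/CC1Cc2c(OC(=O)Nc3ccc(F)cc3)cc(=O)n(CCCO)c2CC1(C)C` keeps that longer chain and alters only the group on the aromatic oxygen: (4-fluorophenyl)carbamoyl in place of benzyl on an oxygen on an aromatic ring. Among the measured compounds shown here, no measured step isolates this position. For the measured compounds named here, the values of compound 1 and compound 2 show merely that a different group there can go together with a large difference, and the single step in hand concerns the chain, not this oxygen, so it points in no direction. Measured against compound 3, the number for compound 4 is therefore expected to lie near 40%, in a wide range from 10% to 70%, amounting to an expected step of a number 6.5 percentage points lower from compound 3 to compound 4 (within the scatter).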

Compound 4, a percentage reported as inhibition, at one concentration (the size of the read-out at that concentration, not a potency): 43.9%
The estimate for compound 4 lay 3.9 percentage points below the measured number, and the stated range covers the measured number.
By their numbers in this assay, from the lowest: compound 1; then compounds 4, 3 and 2 (each within the scatter of the next).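

In this assay, among the compounds shown here, putting (4-fluorophenyl)carbamoyl in place of benzyl on an oxygen on an aromatic ring, with the longer chain held constant, gives the first direct reading of this position: a number 2.6 percentage points lower from compound 3 to compound 4 (within the scatter). On this chain, then, a benzyl ether and an aryl carbamate cannot be told apart at the one concentration tested, even though the entering group brings a hydrogen-bond donor and a hydrogen-bond acceptor that benzyl lacks. Nothing available accounts for this closeness.

Going by these compounds, it remains open whether the same exchange would hold on the shorter chain of compound 1, which gives -0.3% with benzyl on that oxygen. Also open, on these data alone, is how a phenylcarbamoyl group without the fluorine, or a simple acetyl group, would read at this oxygen on either chain.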